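Fluoro to chloro on the benzothiazole of compound 1

The compounds below may be only part of what the source reports. "The series", "measured", "known", "first", "only" and "open" are said of these compounds alone.

Compound 1: `O=C(CNC(=O)c1nn(-c2ccccc2)c(=O)c2ccccc12)Nc1nc2ccc(F)cc2s1` — 470 nM
Compound 2: `COc1ccc2nc(NC(=O)CNC(=O)c3nn(-c4ccccc4OC)c(=O)c4ccccc34)sc2c1` — 90 nM
Compound 3: `COc1ccc(-n2nc(C(=O)NCC(=O)Nc3nc4ccccc4s3)c3ccccc3c2=O)cc1` — 25000 nM

Of the compounds shown here, three have been measured in an assay on L cells for inhibition of Protein-serine O-palmitoleoyltransferase porcupine (Mus musculus), read by reporter gene assay, with a stated time of 24 h; a higher number here means that more compound is needed for the effect, a lower number that less compound is needed. Compound 1 stands second highest of the three numbers. Its nearest neighbour is compound 2, whose value of 90 nM is lower and lies beyond the scatter; the furthest is compound 3, whose value of 25000 nM is higher, also beyond the scatter. No pair among these three differs in only one place, so nothing can be said about the effect of any single change from the measured set alone.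

Compound 4 is `O=C(CNC(=O)c1nn(-c2ccccc2)c(=O)c2ccccc12)Nc1nc2ccc(Cl)cc2s1`, not yet measured. Within the data shown here, the single difference from compound 1 is chloro in place of fluoro on an aromatic carbon. Among the measured compounds shown here, with no comparable step among the measured compounds, the expected step from compound 1 to compound 4 is estimated as small, a 1.3-fold lower number from compound 1 to compound 4 (0.13 log units; within the scatter), and probably within the scatter rather than beyond it. On that basis compound 4 is expected to give about 350 nM, with a likely range from 120 nM to 1000 nM.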

Compound 4, half-maximal effective concentration: 30 nM
Compound 4: the middle estimate sits 12-fold (1.07 log units) above what was measured; the whole stated range lies above it.
By their numbers in this assay, from the lowest: compound 4; then compound 2; then compound 1; then compound 3.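

In this assay, replacing 6-fluoro-1,3-benzothiazol-2-yl with 6-chloro-1,3-benzothiazol-2-yl gives a 16-fold lower number from compound 1 to compound 4 (1.19 log units; beyond the scatter), so exchanging one halogen for the other on this aromatic carbon is enough to produce a large change. Among these compounds, this is the first step in the set that differs in one place, and the first direct sign that the group at this position matters while the rest of compound 1 stays fixed. Nothing available bears on why the two halogens differ so much here.

Going by these compounds, it remains open how bromo, methyl or trifluoromethyl on the same carbon would compare with chloro. Also open, on these data alone, is whether the fluoro-to-chloro exchange would give a step of similar size in the methoxy-bearing compound 2 and compound 3.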